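From Trifluoromethyl to Bromo: One Substitution, One Expectation

The source may report more compounds than this note shows. Statements on the series, on what has been measured and on what is new or still open speak of the compounds shown alone.

Of the compounds shown here, two have been measured in a functional assay on HeLa cells (Homo sapiens) for antiproliferative activity, read by sulforhodamine B assay, with a stated time of 72 h; on this read-out higher numbers stand for weaker inhibition and lower numbers for stronger inhibition. Compound 1 `FC(F)(F)c1ccccc1NC(=S)N/N=C/c1ccc2ccccc2n1` gives 18800 nM, the higher of the two numbers and therefore the weaker inhibitor of the pair. Compound 2 `NC(=S)N/N=C/c1cc2ccccc2s1`, built on a different core, gives 6770 nM in this assay; its number is lower than that of compound 1 by a gap that lies beyond the usual scatter, so compound 2 is the stronger of the two. The two cores differ, so nothing about a single group can be read from this pair.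

Compound 3 `S=C(N/N=C/c1ccc2ccccc2n1)Nc1ccccc1Br` keeps the core of compound 1 and changes one group: bromo in place of trifluoromethyl on an aromatic carbon. The place stays an aromatic carbon of a six-membered aromatic ring of carbon only, ortho to a large group. Among the compounds with values here, no measured pair in this set shows what such a swap does, so the expectation rests on compound 1 alone. The expected change is a 1.4-fold lower number from compound 1 to compound 3 (0.16 log units; within the scatter), most likely within the scatter, with a slight lean toward a lower number. On that basis compound 3 is estimated at 13000 nM in this assay, with a range from 4500 nM to 40000 nM.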

Compound 3, half-maximal inhibitory concentration: > 100000 nM
Compound 3: only a limit was reported (the forecaster's own chance of this, stated with the estimate: 10%); middle value at least 7.6-fold (0.88 log units) from the limit.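

In this assay, compound 3 gives > 100000 nM, and this value is a limit of the assay, not a number. Replacing trifluoromethyl with bromo gives an at least 5.3-fold higher number from compound 1 to compound 3 (0.72 log units; beyond the scatter), so this aromatic carbon, ortho to a large group, is far from indifferent to which of these two groups it carries, even though the rest of the molecule stays the same. The exact size of the loss remains unknown because the reading for compound 3 is only a limit: the limit of > 100000 nM in this assay, at which 1 of the 3 values shown sits.

This single pair cannot show whether the weaker inhibition comes from gaining bromo, losing trifluoromethyl, or both, and no measured property of either group is available to explain the step. The compounds shown also leave open how the shared core would respond to a chloro group, a methoxy group or an amine at this same place, so it is still unclear whether trifluoromethyl is unusually well tolerated here or bromo is unusually poorly tolerated.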